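Inverting one ring stereocentre in compound 3

A few compounds are considered here, and "the series" means these few. Any claim that something is new, unique, unknown or untested is made for them only; others in the source may bear on it.

compound 1 `CC(=O)O[C@@H]1OC(=O)[C@](C)(C(C)=O)[C@@H]1C`: 7000 nM
compound 2 `CC(=O)CC[C@]1(C(C)=O)C(=O)O[C@@H](OC(C)=O)[C@H]1C`: 8000 nM
compound 3 `CC(=O)O[C@@H]1OC(=O)[C@](C)(C(C)=O)[C@@H]1C(C)C`: > 50000 nM

In a functional assay on DA-3 cells for cytotoxicity against DA-3 cell line (Mus musculus), read by MTT assay (on this read-out higher numbers stand for weaker inhibition and lower numbers for stronger inhibition), compound 1 gives 7000 nM. Compound 2 gives 8000 nM in this assay, and the step of a 1.1-fold higher number from compound 1 to compound 2 (0.06 log units; within the scatter) lies within the scatter. For compound 3 only a limit is reported in this assay, namely > 50000 nM. That limit is the limit of > 50000 nM in this assay, at which 1 of the 3 values shown sits. The step of an at least 7.1-fold higher number from compound 1 to compound 3 (0.85 log units; beyond the scatter) is accordingly at least modest. Of the three compounds, compound 3 alone sits at a limit rather than a number.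

Compound 4 `CC(=O)O[C@@H]1OC(=O)[C@@](C)(C(C)=O)[C@@H]1C(C)C` keeps every atom and bond of compound 3 and differs only in configuration: the two compounds have the same atoms and bonds and differ only in configuration as drawn: 1 of 3 stereo elements differ; a stereocentre at a saturated ring carbon is drawn S in compound 3 and R in compound 4. For the measured compounds named here, none of the measured steps inverts a stereocentre, so none bears on this change directly. Going by the values given here, the only step touching compound 3, an at least 7.1-fold higher number from compound 1 to compound 3 (0.85 log units; beyond the scatter), concerns the isopropyl, which compound 4 retains. Compound 4 is therefore expected to remain near the limit, with an estimated step of a number no higher from compound 3 to compound 4 (the limit leaves the size open) that has no settled direction beyond the scatter. The estimate for compound 4 in this assay is 50000 nM, with a range from 12000 nM to 200000 nM, and a fair chance that again only a limit is reported.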

Compound 4, half-maximal inhibitory concentration: > 50000 nM
Compound 4: only a limit was reported; the forecaster's own chance of this, stated with the estimate: 60%; the middle value lies on the limit itself.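

Compound 3 and compound 4 each give only a limit in this assay, so no step can be read between them: the limit of > 50000 nM in this assay, at which 2 of the 4 values shown sit. The compounds shown leave open whether the configuration at this saturated ring carbon changes the read-out in this assay at all.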